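Amide-nitrogen substituents and antiproliferative activity

The source may report more compounds than this note shows. Statements on the series, on what has been measured and on what is new or still open speak of the compounds shown alone.

Compound 1 `CCn1c(C(=O)NC(C)(C)CO)ccc1C(CC)(CC)c1ccc(OCS(=O)(=O)c2ccccc2)c(C)c1` carries a 1-(hydroxymethyl)-1-methylethyl group on the amide-type nitrogen; in a functional assay on BXPC-3 cells (Homo sapiens) for antiproliferative activity, read by MTT assay, with a stated time of 24 h (on this read-out higher numbers stand for weaker inhibition and lower numbers for stronger inhibition), compound 1 gives 18300 nM. Compound 2 `CCn1c(C(=O)N[C@H](CO)C(C)C)ccc1C(CC)(CC)c1ccc(OCS(=O)(=O)c2ccccc2)c(C)c1` bears the 1-(hydroxymethyl)-2-methylpropyl group instead; in this assay compound 2 gives 7720 nM, the step being a 2.4-fold lower number from compound 1 to compound 2 (0.37 log units; beyond the scatter). Compound 3 `CCn1c(C(=O)N[C@@H](CO)CCO)ccc1C(CC)(CC)c1ccc(OCS(=O)(=O)c2ccccc2)c(C)c1` carries the 3-hydroxy-1-(hydroxymethyl)propyl group. For compound 3 only a limit is recorded in this assay: > 50000 nM. Compound 3 therefore sits at the weak end of the three, both steps into it running beyond the scatter: an at least 2.7-fold higher number from compound 1 to compound 3 (0.43 log units; beyond the scatter) and an at least 6.4-fold higher number from compound 2 to compound 3 (0.81 log units; beyond the scatter). Among the measured compounds shown here, compound 3 is the single value sitting at the limit of > 50000 nM in this assay, at which 1 of the 3 values shown sits.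

Compound 4 `CCn1c(C(=O)N[C@@H](CCC(=O)O)C(=O)O)ccc1C(CC)(CC)c1ccc(OCS(=O)(=O)c2ccccc2)c(C)c1` alters the same position once more: 1,3-dicarboxypropyl in place of 3-hydroxy-1-(hydroxymethyl)propyl on an amide-type nitrogen. For the measured compounds named here, no measured step involves a carboxylic acid on this nitrogen; the only steps bearing on the change are those into compound 3, both toward weaker inhibition and ending at a limit. The expected step that the limit leaves unreadable from compound 3 to compound 4 rests on no measured number for compound 3 and is taken as no clear move beyond the scatter. Compound 4 in this assay is estimated at 70000 nM, ranging from 20000 nM to 250000 nM, with a limit rather than a number the likely outcome.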

Compound 4, half-maximal inhibitory concentration: > 50000 nM
Compound 4 was reported as a limit; the forecaster's own chance of this, stated with the estimate: 70%; the middle value is on the limit's open side.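

Compound 4 gives a second entry at the limit in this assay, so the 1,3-dicarboxypropyl group joins the 3-hydroxy-1-(hydroxymethyl)propyl group at the weak end of this position: the limit of > 50000 nM in this assay, at which 2 of the 4 values shown sit.

Against the two compounds with measured numbers, the change runs toward weaker inhibition, beyond the scatter in both cases: an at least 6.4-fold higher number from compound 2 to compound 4 (0.81 log units; beyond the scatter) and an at least 2.7-fold higher number from compound 1 to compound 4 (0.43 log units; beyond the scatter). The step between compound 3 and compound 4 cannot be read, as both records are limits, so no order between these two groups follows from them.

Still open, from the compounds shown here alone, is how far past the limit compound 3 and compound 4 lie, and whether a single carboxylic acid, its methyl ester or an amine on this nitrogen would give a readable number. Also open, going by these compounds, is whether a longer alkyl chain alongside the hydroxymethyl group would lower the number further than the 1-(hydroxymethyl)-2-methylpropyl group, with which compound 2 gives 7720 nM.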